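Cyclohexyl in Place of Methyl: Expected Cytotoxicity

The source may hold more compounds than are shown below. What is called first, only, known or untested is meant among the compounds shown, and "the series" means these compounds.

Compound 1, `CCC(=O)Nc1ccc(-c2nc3cc(C(F)(F)F)ccc3n2C2CCCCC2)cc1`: 17000 nM
Compound 2, `CC(=O)Nc1ccc(-c2nc3cc(C(F)(F)F)ccc3n2C)cc1`: 15000 nM

In an ADME assay on MT4 cells (Homo sapiens) for cytotoxicity, read by MTT assay, with a stated time of 96 h (on this read-out lower numbers stand for higher toxicity in this test and higher numbers for lower toxicity in this test), compound 1 gives 17000 nM and compound 2 gives 15000 nM; the two numbers lie within the scatter of each other, so compound 2 stands level with compound 1 rather than apart from it. Compound 3, `CC(=O)Nc1ccc(-c2nc3cc(C(F)(F)F)ccc3n2C2CCCCC2)cc1`, has not yet been measured. It differs from compound 2 in one place: cyclohexyl in place of methyl on an aromatic nitrogen. For the measured compounds named here, no measured pair shows this change on its own, but compound 1 already carries the cyclohexyl group and gives 17000 nM, close to compound 2. The expected step is therefore a 1.1-fold higher number from compound 2 to compound 3 (0.03 log units; within the scatter), none beyond the scatter. Compound 3 is estimated at 16000 nM, between 8000 nM and 32000 nM.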

Compound 3, half-maximal cytotoxic concentration: 24000 nM
The estimate for compound 3 lay 1.5-fold (0.18 log units) below the measured number; the range from low to high includes it.
By their numbers in this assay, from the lowest: compounds 2, 1 and 3 (each within the scatter of the next).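

In this assay, cyclohexyl in place of methyl on an aromatic nitrogen can now be read on its own, as a 1.6-fold higher number from compound 2 to compound 3 (0.20 log units; within the scatter), so this larger ring leaves the number within the scatter at this position. With cyclohexyl kept, hydrogen in place of methyl on a saturated chain carbon bound to a carbonyl carbon gives a 1.4-fold higher number from compound 1 to compound 3 (0.15 log units; within the scatter), which is also within the scatter. No measurement shown here offers an explanation for these values.

As far as these compounds go, whether phenyl or a chain bearing an amine on the same aromatic nitrogen would move the number beyond the scatter stays open. So does the effect of a carboxylic acid in place of the acyl chain.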